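Triazole-linked flavanone series: nitric oxide inhibition notes

The compounds below may be only part of what the source reports. "The series", "measured", "known", "first", "only" and "open" are said of these compounds alone.

Measured so far:
- compound 1, `C#CCOc1cc(O)c2c(c1)O[C@H](c1ccc(OC)c(O)c1)C/C2=N\O`: 19100 nM
- compound 2, `COc1ccc([C@@H]2CC(=O)c3c(O)cc(OCc4cn(Cc5ccccc5C(F)(F)F)nn4)cc3O2)cc1O`: 12500 nM
- compound 3, `COc1ccc([C@@H]2C/C(=N\O)c3c(O)cc(OCc4cn(Cc5ccccc5C)nn4)cc3O2)cc1O`: 18000 nM

All three were run in a functional assay on RAW264.7 cells (Mus musculus) for inhibition, read by Griess assay, with stated times of 2 h and 24 h; on this read-out lower numbers stand for stronger inhibition and higher numbers for weaker inhibition. Compound 1 gives 19100 nM, compound 3 gives 18000 nM, and compound 2 gives 12500 nM, the lowest number of the three. The gaps from compound 2 to compound 3 and to compound 1 both lie within the scatter of repeated measurements, so no order among the three can be read from these numbers, and none of the three pairs differs in a single place.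

Compound 4, `COc1ccc([C@@H]2CC(=O)c3c(O)cc(OCc4cn(Cc5ccc(Cl)cc5)nn4)cc3O2)cc1O`, is not yet measured. It differs from compound 2 in one place: 4-chlorophenyl in place of 2-(trifluoromethyl)phenyl on a saturated chain carbon bound to an aromatic nitrogen. Among the compounds with values here, no measured pair shows what this kind of exchange does in this assay, so there is nothing to anchor a direction. The step from compound 2 to compound 4 is expected to be small, a 1.0-fold higher number from compound 2 to compound 4 (0.02 log units; within the scatter), with no change beyond the scatter. For compound 4 the expected value in this assay is 13000 nM, with a range from 5000 nM to 35000 nM.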

Compound 4, half-maximal inhibitory concentration: 17800 nM
Estimate against measurement, compound 4: 1.4-fold (0.14 log units) below; the measured number falls inside the stated range.
By their numbers in this assay, from the lowest: compounds 2, 4, 3 and 1 (each within the scatter of the next).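

In this assay the series now has its first comparison in a single place: 4-chlorophenyl in place of 2-(trifluoromethyl)phenyl on a saturated chain carbon bound to an aromatic nitrogen gives a 1.4-fold higher number from compound 2 to compound 4 (0.15 log units; within the scatter) for this exchange. At this place, then, going from 10 heavy atoms to 7, and from three fluorine atoms to one chlorine, leaves the number within the scatter. Nothing measured here speaks to why this step is as it is.

Open, on these data alone, is whether any group at this place can move the number beyond the scatter, as one step on two substituted phenyl groups cannot say. A plain phenyl, or a phenyl carrying an amine or a carboxylic acid, would test that.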